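Swapping a Phenyl Phosphate for a Pyridinium Phosphate

This account rests on a few compounds, and the source may have more. Where it says the series, first, only, none or still open, it means among the compounds named here.

Compound 1 `CCOC(=O)C[n+]1cccc(O)c1`: in a functional assay on U-118-MG cells (Homo sapiens) for cytotoxicity, read by MTT assay, with a stated time of 48 h (a lower number here means a stronger inhibitor, a higher number a weaker inhibitor), compound 1 gives > 200000 nM, which is a limit of the assay and not a number.
Compound 2 `O=C(O[C@H]1C[C@H](n2cc(F)c(=O)[nH]c2=O)O[C@@H]1COP(=O)(O)Oc1ccccc1)c1ccccc1`: compound 2 gives 970 nM in this assay.
Compound 3 `CCCCCCCCCc1ccc(OP(=O)(O)OC[C@H]2O[C@@H](n3cc(F)c(=O)[nH]c3=O)C[C@@H]2OC(=O)c2ccccc2)cc1`: compound 3 gives 11000 nM in this assay.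

Of the two compounds with a numerical result, compound 2 stands lowest, so it is the stronger inhibitor of the pair. Its nearest neighbour is compound 3, and the step of an 11-fold higher number from compound 2 to compound 3 (1.05 log units; beyond the scatter) shows that a nonyl in place of hydrogen on an aromatic carbon weakens the effect clearly.

Compound 4 `C[n+]1cccc(OP(=O)([O-])OC[C@H]2O[C@@H](n3cc(F)c(=O)[nH]c3=O)C[C@@H]2OC(=O)c2ccccc2)c1` differs from compound 2 in one place: a group of 11 heavy atoms (6 carbon, 1 nitrogen, 3 oxygen, 1 phosphorus; one six-membered aromatic ring with 1 hetero atom) in place of a group of 10 heavy atoms (6 carbon, 3 oxygen, 1 phosphorus; one six-membered aromatic ring of carbon only), on an oxygen on a saturated carbon. For the measured compounds named here, no measured step covers this kind of exchange. Going by the values given here, the only step known, an 11-fold higher number from compound 2 to compound 3 (1.05 log units; beyond the scatter), concerns a different change, so it offers no direct guide, and a modest shift in either direction cannot be ruled out. The expected step is a 2.1-fold higher number from compound 2 to compound 4 (0.31 log units; beyond the scatter), leaning toward a slightly higher number. Compound 4 is therefore estimated at 2000 nM, with a range from 500 nM to 8000 nM.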

Compound 4, half-maximal inhibitory concentration: 3150 nM
Compound 4: middle estimate off by 1.6-fold (0.20 log units), on the low side; the measured number falls inside the stated range.
By their numbers in this assay, from the lowest: compound 2; then compound 4; then compound 3. At a limit, above all of these: compound 1.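

Exchanging the six-membered aromatic ring of carbon only for one with 1 hetero atom, on an oxygen on a saturated carbon, gives a 3.2-fold higher number from compound 2 to compound 4 (0.51 log units; beyond the scatter) in this assay. Until now the only change shown at this end of the molecule was the added nonyl; this result shows that the ring itself can be exchanged at a modest cost, with compound 2 still giving the lower number of the pair. Nothing measured here explains why the number rises with this exchange.

Going by these compounds, it remains open how the ring with 1 hetero atom would behave if it carried a nonyl, an amine or a carboxylic acid. On these data alone, it is also open whether a shorter chain, such as ethyl, on the carbon-only ring would raise the number as nonyl does.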